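The source may hold more compounds than are shown below. What is called first, only, known or untested is meant among the compounds shown, and "the series" means these compounds.

compound 1 `Oc1cccc(-c2nnc(Nc3cccc(F)c3)s2)c1`: 170000 nM
compound 2 `Clc1ccc(-c2nnc(Nc3ccc(Br)cc3)s2)c(Cl)c1`: 70000 nM

Both numbers come from a functional assay on MDA-MB-231 cells (Homo sapiens) for antiproliferative activity, read by MTT assay, with a stated time of 24 h; a lower number here means a stronger inhibitor, a higher number a weaker inhibitor. Compound 2 holds the lower of the two, and its gap to compound 1 lies beyond the scatter. The two compounds differ in more than one place, so that gap cannot be tied to a single change.

Compound 3 `Fc1ccc(Nc2nnc(-c3ccc(Cl)cc3Cl)s2)cc1`, not yet measured, departs from compound 2 by fluoro in place of bromo on an aromatic carbon, para to a large group. Among the compounds with values here, no pair of measured compounds shows this exchange directly. Within the data shown here, the only measured compound with a fluoro group is compound 1 at 170000 nM, which is weak support at best. A modest rise is expected, a 1.3-fold higher number from compound 2 to compound 3 (0.11 log units; within the scatter), and it may stay within the scatter. For compound 3 the estimated value is 90000 nM, with an expected range of 35000 nM to 220000 nM.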

Compound 3, half-maximal inhibitory concentration: 130000 nM
Estimate against measurement, compound 3: 1.4-fold (0.16 log units) below, and the stated range covers the measured number.
By their numbers in this assay, from the lowest: compounds 2, 3 and 1 (each within the scatter of the next, the first and the last beyond it).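

The pair of compound 2 and compound 3 gives the series its first comparison that differs in one place: 4-bromophenyl to 4-fluorophenyl, on an aromatic carbon para to a large group. In this assay this exchange gives a 1.9-fold higher number from compound 2 to compound 3 (0.27 log units; within the scatter), so bromo and fluoro at this position are not separated by this read-out. No measurement available here bears on the reason for this reading.

Compound 1 differs from compound 2 and from compound 3 in more than one place, so no single change can yet be tied to its printed value. Also open, from the compounds shown here alone, is how a methoxy group or an amine at this position would read against bromo and fluoro.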